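The compounds below may be only part of what the source reports. "The series", "measured", "known", "first", "only" and "open" are said of these compounds alone.

In a functional assay on HepG2 cells (Homo sapiens) for cytotoxicity, read by MTT assay, with a stated time of 48 h (on this read-out higher numbers stand for weaker inhibition and lower numbers for stronger inhibition), compound 1 (`COc1ccc(/C=C/C(=O)/C=C/c2nc3cc(C)ccc3n2C)cc1O`) gives 3300 nM and compound 2 (`COc1ccc(/C=C/C(=O)/C=C/c2nc3c(C)c(C)ccc3n2C)cc1O`) gives 3900 nM, so the two stand level within the scatter. Compound 3 (`COc1ccc(/C=C/C(=O)/C=C/c2nc3cc(Cl)ccc3n2C)cc1O`) has chloro in place of methyl on an aromatic carbon of the core of compound 1: chloro in place of methyl on an aromatic carbon. For the measured compounds named here, the only measured step is a 1.2-fold higher number from compound 1 to compound 2 (0.07 log units; within the scatter), a methyl in place of hydrogen on an aromatic carbon. That is a different change and only a loose guide, so no shift beyond the scatter is expected in this assay. The expected step is a 1.1-fold lower number from compound 1 to compound 3 (0.04 log units; within the scatter). For compound 3 the estimated value is 3000 nM, with an expected range of 1400 nM to 6500 nM.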

Compound 3, half-maximal inhibitory concentration: 4100 nM
Estimate against measurement, compound 3: 1.4-fold (0.14 log units) below; low and high end bracket the measured number.
By their numbers in this assay, from the lowest: compounds 1, 2 and 3 (each within the scatter of the next).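

The methyl on this aromatic carbon of the six-membered ring can be exchanged for chloro with no shift beyond the scatter: in this assay the change gives a 1.2-fold higher number from compound 1 to compound 3 (0.09 log units; within the scatter). The earlier compounds shown here showed only a methyl added to the core, whereas this pair replaces the existing group, so this position has now tolerated two different substituents in this read-out. Nothing available explains this result.

From the compounds shown here alone, whether an amine, a carboxylic acid or a longer chain on this carbon would move the number beyond the scatter remains open.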